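Bromo for tert-butyl: compound 2 to compound 4

The compounds below may be only part of what the source reports. "The series", "measured", "known", "first", "only" and "open" are said of these compounds alone.

Measured compounds in a functional assay on PC-3 cells (Homo sapiens) for antiproliferative activity, read by MTT assay, with a stated time of 72 h; a higher number here means a weaker inhibitor, a lower number a stronger inhibitor:
- compound 1 `O=C1OCC[C@@H]1NC(=S)SCCOc1ccccc1Cc1ccccc1`: > 64000 nM, a limit of the assay.
- compound 2 `CC(C)(C)c1ccc(/C=C/C(=O)c2ccc(OCC(=O)N[C@H]3CCOC3=O)cc2)cc1`: 10600 nM.
- compound 3 `C=CCc1ccc(OCCSC(=S)N[C@H]2CCOC2=O)c(OC)c1`: > 64000 nM, a limit of the assay.

For the measured compounds named here, compound 2 is the only member of the series that returns a number in this assay. The other two sit at the same limit, which is the limit of > 64000 nM in this assay, at which 2 of the 3 values shown sit, and carry no number. Going by the values given here, compound 1 and compound 3 share a thiocarbamate link to the lactone; compound 2 differs in several places at once, so no single step between measured compounds can be drawn and no part of the difference between them can be assigned.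

Compound 4 `O=C(COc1ccc(C(=O)/C=C/c2ccc(Br)cc2)cc1)N[C@H]1CCOC1=O` is the next compound to be measured. It differs from compound 2 in one place: bromo in place of tert-butyl on an aromatic carbon. Among the compounds with values here, nothing among the measured compounds shows what such a change does in this assay, so the size of the step is open. A modest step, in either direction, is the expectation, and a step within the scatter is as likely as anything else.

Compound 4 is estimated at 15000 nM, within 5000 nM to 45000 nM, which means an expected step of a 1.4-fold higher number from compound 2 to compound 4 (0.15 log units; within the scatter).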

Compound 4, half-maximal inhibitory concentration: > 64000 nM
Compound 4 gave a limit, no number (the forecaster's own chance of this, stated with the estimate: 15%); middle value at least 4.2-fold (0.63 log units) from the limit.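

In this assay, bromo in place of tert-butyl on an aromatic carbon, para to a large group, gives an at least 6.0-fold higher number from compound 2 to compound 4 (0.78 log units; beyond the scatter). For the compounds shown here, this is the first one-place step that can be read, and it shows that the change from 4-(tert-butyl)phenyl to 4-bromophenyl is not neutral here: the antiproliferative activity seen with compound 2 does not survive it at a level this assay can put a number on, so the step is a lower bound and its full size stays unknown. Compound 4 carries a limit and no number, and with it the limit becomes the usual outcome among the compounds shown: the limit of > 64000 nM in this assay, at which 3 of the 4 values shown sit.

The compounds shown leave open whether the step follows from removing tert-butyl or from introducing bromo, and a single pair cannot separate the two. An isopropyl group, a methoxy group or an amine at this same place on the ring would show whether any other group keeps a measurable value or whether tert-butyl stands alone.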